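Urea series on a shared core: carboxy to methylsulfanyl

A few compounds are considered here, and "the series" means these few. Any claim that something is new, unique, unknown or untested is made for them only; others in the source may bear on it.

Working notes on three ureas built on the shared core of compound 1 `Cc1cc(NC(=O)Nc2ccc(C(=O)O)cc2)c2ccccc2n1`. In an ADME assay on BJ cells (Homo sapiens) for cytotoxicity, with a stated time of 72 h (on this read-out lower numbers stand for an effect already at smaller amounts and higher numbers for an effect only at larger amounts of compound), compound 1 reaches only the limit of the assay and no number, > 25000 nM. This is the line (the limit of > 25000 nM in this assay, at which 1 of the 2 values shown sits), so compound 1 cannot be placed more exactly than at that limit. Compound 2 `Cc1cc(NC(=O)Nc2cc(F)ccc2F)c2ccccc2n1`, which carries a different aryl group on the urea, gives a number in this assay, 7000 nM.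

Compound 3 `CSc1ccc(NC(=O)Nc2cc(C)nc3ccccc23)cc1` is not yet measured. It differs from compound 1 by methylsulfanyl in place of carboxy on an aromatic carbon. Within the data shown here, no measured step covers such a change here. The value of compound 2, 7000 nM, shows that a neutral aryl partner on this core can give a number within the range of this assay. The step from compound 1 to compound 3 is therefore expected to run toward smaller amounts, an at least 2.7-fold lower number from compound 1 to compound 3 (0.44 log units; beyond the scatter). Compound 3 is estimated at 9000 nM, with a range from 3000 nM to 25000 nM, and a real chance that only a limit is reported.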

Compound 3, half-maximal effective concentration: > 25000 nM
Compound 3 was reported as a limit (the forecaster's own chance of this, stated with the estimate: 30%); middle value at least 2.7-fold (0.44 log units) away from the limit.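

Compound 1 and compound 3 both stand only as limits in this assay, so no step between them can be read: the limit of > 25000 nM in this assay, at which 2 of the 3 values shown sit.

The compounds shown leave open whether methylsulfanyl in place of carboxy on an aromatic carbon changes the read-out at all, and in which direction.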